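The compounds below may be only part of what the source reports. "The series", "measured", "known", "first", "only" and "open" are said of these compounds alone.

The measured compounds:
Compound 1 `CCn1c([C@@H](C)NS(=O)(=O)c2ccc(Cl)cc2)nc2ccccc21`: in an ADME assay (liver) for metabolic stability, with Liver microsome (Homo sapiens) as the target, read by LC-MS, using microsomes and NADPH, with a stated time of 5 min, at 37 degrees C (on this read-out lower numbers stand for slow clearance and higher numbers for fast clearance), compound 1 gives > 100 mL.min-1.g-1, which is a limit of the assay.
Compound 2 `CCn1c([C@@H](C)NS(=O)(=O)c2ccc(Cl)cc2)nc2cc(CO)ccc21`: in this assay compound 2 gives 88 mL.min-1.g-1.
Compound 3 `CCn1c([C@@H](C)NS(=O)(=O)C2CC2)nc2ccc(C(F)(F)F)cc21`: in this assay compound 3 gives < 3 mL.min-1.g-1, which is a limit of the assay.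

Compound 3 thus sits at the limit of < 3 mL.min-1.g-1 in this assay, at which 1 of the 3 values shown sits, while compound 1 sits at the limit of > 100 mL.min-1.g-1 in this assay, at which 1 of the 3 values shown sits, and compound 2 lies close to compound 1. Among the compounds with values here, the only measured step, an at least 1.1-fold lower number from compound 1 to compound 2 (0.05 log units; that floor lies within the scatter), concerns hydroxymethyl in place of hydrogen on an aromatic carbon and lies within the scatter, so it says nothing about the sulfonyl substituent.

Compound 4 `CCn1cc(S(=O)(=O)N[C@H](C)c2nc3ccc(C(F)(F)F)cc3n2CC)cn1` differs from compound 3 by 1-ethyl-1H-pyrazol-4-yl in place of cyclopropyl on a sulfonyl sulfur. Within the data shown here, no measured step touches the group on the sulfonyl sulfur; compounds 1 and 2 differ from compound 3 in more than one place, so their fast clearance cannot be assigned to that group alone. The expected step of an at least 2.6-fold higher number from compound 3 to compound 4 (0.42 log units; beyond the scatter) is therefore a modest rise in the number, not clearly beyond the scatter. Compound 4 is estimated at 8 mL.min-1.g-1, in a range from 3 mL.min-1.g-1 to 30 mL.min-1.g-1, with a real chance that the assay again reports only a limit.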

Compound 4, intrinsic clearance in microsomes: 95 mL.min-1.g-1
Compound 4: middle estimate off by 12-fold (1.07 log units), on the low side; the whole stated range lies below it.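

With the rest of the molecule held constant, the group on the sulfonyl sulfur proves decisive on its own in this assay: 1-ethyl-1H-pyrazol-4-yl in place of cyclopropyl produces a large rise in the number (an at least 31-fold higher number from compound 3 to compound 4 (1.50 log units; beyond the scatter)). Within the data shown here, compounds 1 and 2 differ from compound 3 in more than one place, so this is the first pair in which this single change can be read by itself. The size of the step is only a floor, since the value of compound 3 is a limit of the assay: the limit of < 3 mL.min-1.g-1 in this assay, at which 1 of the 4 values shown sits.

The compounds shown leave open whether the rise follows the ethyl chain or the pyrazole ring itself, which a 1H-pyrazol-4-yl without the ethyl or a 1-methyl-1H-pyrazol-4-yl group on the sulfonyl sulfur would separate. They also leave open where on compound 4 the clearance takes place.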